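The source may report more compounds than this note shows. Statements on the series, on what has been measured and on what is new or still open speak of the compounds shown alone.

Measured in a functional assay on U-87MG ATCC cells (Homo sapiens) for cytotoxicity, read by MTT assay, with a stated time of 48 h; on this read-out lower numbers stand for stronger inhibition and higher numbers for weaker inhibition:
- compound 1 `C/C(=N\NC(=S)Nc1cccc(F)c1)c1ccccn1`: 18 nM
- compound 2 `C/C(=N\NC(=S)Nc1ccccc1)c1ccccn1`: 1.4 nM
- compound 3 `C/C(=N\NC(=S)Nc1cccc(I)c1)c1ccccn1`: 84 nM

Compound 1 holds the middle place among these three numbers. The step upward is a 4.7-fold higher number from compound 1 to compound 3 (0.67 log units; beyond the scatter), and the step downward is a 13-fold lower number from compound 1 to compound 2 (1.11 log units; beyond the scatter). The unmeasured compound 4 `C/C(=N/NC(=S)Nc1cccc(F)c1)c1ccccn1` is the geometric partner of compound 1. The change is the two compounds have the same atoms and bonds and differ only in configuration as drawn: 1 of 1 stereo elements differ; a double bond is drawn E in compound 1 and Z in compound 4. No atom or bond leaves or enters.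

Among the compounds with values here, none of the measured steps tests this kind of change. All three replace a substituent on an aromatic carbon, and the configuration of the double bond stays the same. They show only that this assay can respond strongly to a small edit: a 60-fold higher number from compound 2 to compound 3 (1.78 log units; beyond the scatter) is large, as is a 13-fold lower number from compound 1 to compound 2 (1.11 log units; beyond the scatter), while a 4.7-fold higher number from compound 1 to compound 3 (0.67 log units; beyond the scatter) is modest. These steps give no direction for the change in configuration, and they offer no assurance that it would be silent. The best expectation therefore stays close to compound 1, with a wide margin on both sides. The expected change is a 1.1-fold higher number from compound 1 to compound 4 (0.05 log units; within the scatter), a step not expected to go beyond the scatter, though a larger one in either direction remains possible. The estimated value for compound 4 is 20 nM, with an expected range from 4 nM to 100 nM.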

Compound 4, half-maximal inhibitory concentration: 18 nM
Estimate against measurement, compound 4: 1.1-fold (0.05 log units) above, and the stated range covers the measured number.
By their numbers in this assay, from the lowest: compound 2; then compounds 1 and 4 (each within the scatter of the next); then compound 3.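

In this assay, the configuration of the double bond is now tested directly, and the result is no change at the digits printed from compound 1 to compound 4 (within the scatter). All three earlier steps replaced a substituent on an aromatic carbon and lay beyond the scatter, so they showed that this assay can respond strongly to a small edit; this step shows that such a response does not extend to every small edit, at least for the fluoro compounds. The flat result can be read against the configuration alone, since no atom or bond leaves or enters and nothing else separates the pair: the fact that compounds 1 and 4 differ only in the configuration as drawn.

This single pair cannot say whether the configuration would stay equally silent with the hydrogen of compound 2 or the iodo group of compound 3 on the aromatic carbon, nor can it say why the drawn configuration makes no visible difference here. Also open, as far as these compounds go, is how a methoxy group, an amine or a carboxylic acid on that same aromatic carbon would read, in either configuration of the double bond.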